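Hydroxy in place of propyl on compound 1

The source may report more compounds than this note shows. Statements on the series, on what has been measured and on what is new or still open speak of the compounds shown alone.

Compound 1 `CCCCC(CCO)n1cnc2c(Cl)ncnc21` gives > 50000 nM in a functional assay on SW480 cells (Homo sapiens) for antiproliferative activity, read by MTT assay, with a stated time of 48 h (a higher number here means a weaker inhibitor, a lower number a stronger inhibitor), and this is a limit, not a number. Compound 3 `CCCCCCCCCCCCC(CCO)n1cnc2c(Cl)ncnc21` gives > 50000 nM, again only a limit. Compound 1 thus stands at the limit of > 50000 nM in this assay, at which 2 of the 3 values shown sit. Only compound 2 `CCCCCCCCCC(CCO)n1cnc2c(Cl)ncnc21` gives a number, 1150 nM.

The two readable steps both add chain carbons. Pentyl in place of hydrogen gives an at least 43-fold lower number from compound 1 to compound 2 (1.63 log units; beyond the scatter), and propyl in place of hydrogen then gives an at least 43-fold higher number from compound 2 to compound 3 (1.63 log units; beyond the scatter). Both are large, and compound 3 goes against any trend that a longer chain means a lower number.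

Compound 4 `OCCC(CO)n1cnc2c(Cl)ncnc21` differs from compound 1 by hydroxy in place of propyl on a saturated chain carbon, two bonds along the chain from an aromatic nitrogen. Cut one bond further out, this reads butyl to hydroxymethyl. Among the measured compounds shown here, no measured step makes this change, so the evidence is indirect: the only drop to a measurable number, an at least 43-fold lower number from compound 1 to compound 2 (1.63 log units; beyond the scatter), came from adding chain, whereas this change takes chain away.

No drop is therefore expected in this assay, and the estimated step is a step that the limit leaves unreadable from compound 1 to compound 4. Compound 4 is expected at 60000 nM, with an estimated range of 25000 nM to 150000 nM.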

Compound 4, half-maximal inhibitory concentration: > 50000 nM
Compound 4 was reported as a limit; the forecaster's own chance of this, stated with the estimate: 85%; the middle value lies beyond the limit too.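

In this assay compound 4 gives > 50000 nM, a limit and not a number. Compound 1 also has only a limit, so no step between compound 1 and compound 4 can be read: the limit of > 50000 nM in this assay, at which 3 of the 4 values shown sit.

The compounds shown leave open how far hydroxy in place of propyl moves the number, and whether any compound without the chain of compound 2 reaches a measurable value.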